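From Nitro to Chloro in an Antiproliferative Series

The source may report more compounds than this note shows. Statements on the series, on what has been measured and on what is new or still open speak of the compounds shown alone.

Among the measured compounds shown here, in a functional assay on HCT-116 cells (Homo sapiens) for antiproliferative activity, read by CCK-8 assay, with a stated time of 72 h (on this read-out lower numbers stand for stronger inhibition and higher numbers for weaker inhibition), compound 1 `Cc1cc(Nc2cc(N3CCN(C)CC3)nc(Nc3ccc(S(N)(=O)=O)cc3)n2)n[nH]1` gives 12200 nM, while compound 2 `Cc1cc(Nc2cc(N3CCN(C)CC3)nc(Nc3ccc([N+](=O)[O-])cc3)n2)n[nH]1` gives 1630 nM, the lowest of the two numbers so far. Compound 3 `Cc1cc(Nc2cc(N3CCN(C)CC3)nc(Nc3ccc(Cl)cc3)n2)n[nH]1` keeps the shared core and differs from compound 2 by one substitution: chloro in place of nitro on an aromatic carbon. In words, this is chloro in place of nitro on an aromatic carbon, para to a large group.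

For the measured compounds named here, only one measured step bears on this change, and it replaced sulfamoyl with nitro at that same place. That step, a 7.5-fold lower number from compound 1 to compound 2 (0.87 log units; beyond the scatter), was modest but beyond the scatter, so the place can move the number in this assay. However, no measured compound carries chloro, and the data give no firm direction for this swap. A smaller step is therefore expected, with a slight lean towards a higher number and quite possibly nothing beyond the scatter.

For compound 3 the estimate is 2200 nM, with an expected range of 750 nM to 6500 nM. This expected value amounts to a 1.3-fold higher number from compound 2 to compound 3 (0.13 log units; within the scatter).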

Compound 3, half-maximal inhibitory concentration: 1370 nM
For compound 3 the middle estimate is 1.6-fold (0.21 log units) above the measured one; the measured number falls inside the stated range.
By their numbers in this assay, from the lowest: compounds 3 and 2 (each within the scatter of the next); then compound 1.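

In this assay, the exchange of nitro for chloro gives a 1.2-fold lower number from compound 2 to compound 3 (0.08 log units; within the scatter). At this aromatic carbon, para to a large group, the two groups therefore cannot be told apart, even though chloro has 1 heavy atom against the 3 of nitro and 0 hydrogen-bond acceptors against 2. Chloro in place of sulfamoyl gives an 8.9-fold lower number from compound 1 to compound 3 (0.95 log units; beyond the scatter), a modest step that shows a second group separating from sulfamoyl at this place, so among these three compounds only the sulfamoyl compound stands apart. Nothing available accounts for this outcome in terms of the groups themselves.

What the compounds shown leave open is how other groups at this place would read, such as an amine, a carboxylic acid, a methoxy group or a longer chain, and whether any would fall on either side of the range these three span. From the compounds shown here alone, it also remains open whether chloro and nitro would stay this close if the shared core were changed elsewhere.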